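This account rests on a few compounds, and the source may have more. Where it says the series, first, only, none or still open, it means among the compounds named here.

Compound 3 (`S=C(N/N=C1\CC2(CCCCC2)Oc2c1ccc1ccccc21)NC1CCCCC1`) gives 7440 nM in a functional assay on HT-29 cells (Homo sapiens) for antiproliferative activity, read by MTT assay, with a stated time of 96 h; on this read-out lower numbers stand for stronger inhibition and higher numbers for weaker inhibition. That places it within the scatter of both neighbours: compound 1 (`S=C(N/N=C1\CC2(CCCCC2)Oc2c1ccc1ccccc21)N1CCCCC1`) gives 6770 nM and compound 2 (`S=C(N/N=C1\CC2(CCCCC2)Oc2c1ccc1ccccc21)N1CCOCC1`) gives 9310 nM, so no order can be drawn among the three. The next structure is compound 4 (`N/N=C1\CC2(CCCCC2)Oc2c1ccc1ccccc21`), and the change is a hydrogen atom in place of a group of 9 heavy atoms (7 carbon, 1 nitrogen, 1 sulfur; one six-membered non-aromatic ring of carbon only), on an amine nitrogen. The measured steps, a 1.1-fold higher number from compound 1 to compound 3 (0.04 log units; within the scatter), a 1.3-fold lower number from compound 2 to compound 3 (0.10 log units; within the scatter) and a 1.4-fold higher number from compound 1 to compound 2 (0.14 log units; within the scatter), all lie within the scatter. However, each one only exchanges the group on the thiocarbonyl carbon, and none removes that carbon, so they give no direct size for this larger change. Among the compounds with values here, no measured compound lacks the thiocarbonyl carbon. A step beyond the scatter toward a higher number in this assay is therefore a cautious expectation, not a firm one. The expected step is a 1.9-fold higher number from compound 3 to compound 4 (0.27 log units; within the scatter). For compound 4 the estimated value is 14000 nM, with an expected range of 5000 nM to 40000 nM.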

Compound 4, half-maximal inhibitory concentration: 9970 nM
The estimate for compound 4 lay 1.4-fold (0.15 log units) above the measured number; measured number inside the range.
By their numbers in this assay, from the lowest: compounds 1, 3, 2 and 4 (each within the scatter of the next).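

In this assay, the thiocarbonyl carbon and the group it bears can be replaced together by a hydrogen atom on the amine nitrogen, and the number stays within the scatter of all three thiocarbonyl compounds (a 1.3-fold higher number from compound 3 to compound 4 (0.13 log units; within the scatter); a 1.1-fold higher number from compound 2 to compound 4 (0.03 log units; within the scatter); a 1.5-fold higher number from compound 1 to compound 4 (0.17 log units; within the scatter)). The earlier steps shown here only exchanged the group on that carbon, whereas these steps show that losing the whole unit also gives no difference this read-out can separate. No measured evidence bears on this result.

Still open, as far as these compounds go, is whether any group on this amine nitrogen moves the number beyond the scatter, such as an acetyl group, a urea carbonyl in place of the thiocarbonyl, or a longer chain ending in an amine. Also open, from the compounds shown here alone, is whether a change on the shared core, such as a carboxylic acid, would do so.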